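Replacing benzyloxy with phenyl in compound 1

The source may report more compounds than this note shows. Statements on the series, on what has been measured and on what is new or still open speak of the compounds shown alone.

Compound 1 `NC(=O)N(O)CC1=Cc2cc(OCc3ccccc3)ccc2OC1` gives 440 nM in an assay (Cavia porcellus) for inhibition of Polyunsaturated fatty acid 5-lipoxygenase (Homo sapiens) (a higher number here means a weaker inhibitor, a lower number a stronger inhibitor), the highest of the three numbers recorded. Compound 2 `NC(=O)N(O)CC1=Cc2cc(OCc3ccc(C(F)(F)F)cc3)ccc2OC1` gives 430 nM, and the step of a 1.0-fold lower number from compound 1 to compound 2 (0.01 log units; within the scatter) lies within the scatter. Compound 3 `CC(C)NC(=O)N(O)CC1=Cc2cc(Oc3ccccc3)ccc2OC1` gives 49 nM; it differs from compound 1 in more than one place, so only its value is noted. Compound 4 `NC(=O)N(O)CC1=Cc2cc(-c3ccccc3)ccc2OC1` carries the change (phenyl in place of benzyloxy on an aromatic carbon). Among the compounds with values here, no measured step covers this exchange: the one step at this position, a 1.0-fold lower number from compound 1 to compound 2 (0.01 log units; within the scatter), adds a trifluoromethyl and moves nothing beyond the scatter. For compound 4 the expectation is therefore a modest step toward a higher number, a 1.5-fold higher number from compound 1 to compound 4 (0.17 log units; within the scatter), carrying wide uncertainty. Compound 4 is estimated at 650 nM, with a range from 150 nM to 2800 nM.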

Compound 4, half-maximal inhibitory concentration: 240 nM
Estimate against measurement, compound 4: 2.7-fold (0.43 log units) above; the range from low to high includes it.
By their numbers in this assay, from the lowest: compound 3; then compounds 4, 2 and 1 (each within the scatter of the next).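

In this assay, phenyl in place of benzyloxy gives a 1.8-fold lower number from compound 1 to compound 4 (0.26 log units; within the scatter). Where the earlier step changed only a substituent on the benzyloxy ring, this one alters the group on the aromatic carbon itself, and an aromatic ring attached directly to the core stays within the scatter of compound 1. No measurement available here accounts for this result.

Still open, going by these compounds, is how an amine or a carboxylic acid on the phenyl ring of compound 4 would read in this assay. On these data alone, a longer chain in place of phenyl also remains untested in these compounds.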